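Amide Variation on a Dienamide Alcohol Scaffold

This account rests on a few compounds, and the source may have more. Where it says the series, first, only, none or still open, it means among the compounds named here.

Compound 1 `CCNC(=O)/C=C/C=C/[C@H](O)Cc1ccc(OC)c(OC)c1` and compound 2 `COc1ccc(C[C@@H](O)/C=C/C=C/C(=O)N2CCCCC2)cc1OC` share a core that differs only at the amide. In a functional assay on HeLa cells (Homo sapiens) for antiproliferative activity, read by sulforhodamine B assay, with a stated time of 48 h (a lower number here means a stronger inhibitor, a higher number a weaker inhibitor), compound 1 gives 14600 nM, and compound 2 gives 14100 nM; the step of a 1.0-fold lower number from compound 1 to compound 2 (0.02 log units; within the scatter) shows that the two amides are indistinguishable within this assay's scatter. Within the data shown here, compound 2 thus stands level with the only other measured compound.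

Compound 3 `COc1ccc(C[C@@H](O)/C=C/C=C/C(=O)NCc2ccc(Cl)cc2)cc1OC` is the next member of the set, and its change from compound 2 is (4-chlorobenzyl)amino in place of piperidin-1-yl on a carbonyl carbon. Among the measured compounds shown here, the only step that bears on it is the amide exchange from compound 1 to compound 2, which was a 1.0-fold lower number from compound 1 to compound 2 (0.02 log units; within the scatter), so the amide has so far tolerated a change without moving the number. For the measured compounds named here, the (4-chlorobenzyl)amino group is larger than either earlier amide, and it carries a hydrogen-bond donor that piperidin-1-yl lacks, but there is no measured step on such a group. Compound 3 is therefore expected to stay near compound 2, with a step of a 1.4-fold lower number from compound 2 to compound 3 (0.15 log units; within the scatter) in this assay. Compound 3 is estimated at 10000 nM, in a range from 3000 nM to 30000 nM.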

Compound 3, half-maximal inhibitory concentration: 13400 nM
For compound 3 the middle estimate is 1.3-fold (0.13 log units) below the measured one, within the range that was stated.
By their numbers in this assay, from the lowest: compounds 3, 2 and 1 (each within the scatter of the next).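

Putting (4-chlorobenzyl)amino in place of piperidin-1-yl on a carbonyl carbon adds an aromatic ring and the amide hydrogen, yet this assay records a 1.1-fold lower number from compound 2 to compound 3 (0.02 log units; within the scatter) and so no readable change. Against the ethylamino amide the picture is the same: 4-chlorophenyl in place of methyl on a saturated chain carbon bound to an amide-type nitrogen gives a 1.1-fold lower number from compound 1 to compound 3 (0.04 log units; within the scatter) and thus extends the tolerance seen so far to a larger group carrying an aromatic ring. Nothing available explains why these three amides sit level.

Still open is whether the chlorine matters at all, as a plain benzylamino group is not among the compounds shown. As far as these compounds go, it is also open whether a carboxylic acid in place of the amide would move the number, since all three compounds keep the amide.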